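A few compounds are considered here, and "the series" means these few. Any claim that something is new, unique, unknown or untested is made for them only; others in the source may bear on it.

- compound 1 `COc1ccc(Cl)cc1-c1cc(Nc2ccc(Cl)cc2)nc(N)n1` gives 150 nM
- compound 2 `CCOc1ccc(Br)cc1-c1cc(Nc2ccc(C#N)cc2)nc(N)n1` gives 70 nM
- compound 3 `CCOc1ccc(Br)cc1-c1cc(Nc2cccc(C#N)c2)nc(N)n1` gives 350 nM

In a functional assay on K562 cells (Homo sapiens) for inhibition (a higher number here means a weaker inhibitor, a lower number a stronger inhibitor), compound 3 has the highest number of the three and is the weakest inhibitor so far. Compound 4 `CCOc1ccc(Br)cc1-c1cc(Nc2ccc(C(C)=O)cc2)nc(N)n1` carries 4-acetylphenyl in place of 3-cyanophenyl on a nitrogen on an aromatic ring. Among the measured compounds shown here, the one measured step that bears on this change is a 5.0-fold higher number from compound 2 to compound 3 (0.70 log units; beyond the scatter) with 3-cyanophenyl replacing 4-cyanophenyl. The 4-acetylphenyl of compound 4 reads closer to the 4-cyanophenyl of compound 2 (70 nM) than to 3-cyanophenyl, so much of that step is expected to be regained, although no acetyl group has been measured. The expected change is a 3.2-fold lower number from compound 3 to compound 4 (0.50 log units; beyond the scatter) in this assay toward a stronger inhibitor. For compound 4 the estimate is 110 nM with an expected range from 40 nM to 300 nM for now.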

Compound 4, half-maximal inhibitory concentration: 50 nM
For compound 4 the middle estimate is 2.2-fold (0.34 log units) above the measured one, within the range that was stated.
By their numbers in this assay, from the lowest: compounds 4 and 2 (each within the scatter of the next); then compound 1; then compound 3.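

In this assay, 4-acetylphenyl in place of 3-cyanophenyl on the nitrogen gives a 7.0-fold lower number from compound 3 to compound 4 (0.85 log units; beyond the scatter), while acetyl in place of cyano gives a 1.4-fold lower number from compound 2 to compound 4 (0.15 log units; within the scatter). At this nitrogen, then, 4-acetylphenyl and 4-cyanophenyl perform alike, so a nitrile is not required for the lower number seen with compound 2. No measurement shown gives a reason for this result. From the compounds shown here alone, what a carboxylic acid or an amine would do in place of the acetyl remains open. So does whether 3-acetylphenyl would give a higher number than 4-acetylphenyl, as 3-cyanophenyl does than 4-cyanophenyl.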